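This account rests on a few compounds, and the source may have more. Where it says the series, first, only, none or still open, it means among the compounds named here.

Measured so far, in a functional assay on MOLT-4 cells (Homo sapiens) for antiproliferative activity; on this read-out lower numbers stand for stronger inhibition and higher numbers for weaker inhibition:
- compound 1 `COc1cc(C(=O)c2sc(-c3ccc(Cl)cc3)cc2N)cc(OC)c1OC`: 77 nM
- compound 2 `COc1cc(C(=O)c2sc(-c3ccc(C(F)(F)F)cc3)cc2N)cc(OC)c1OC`: 250 nM
- compound 3 `CCOc1ccc(-c2cc(N)c(C(=O)c3cc(OC)c(OC)c(OC)c3)s2)cc1`: 240 nM

Compound 1 holds the lowest number of the three; compound 3 sits a 3.1-fold higher number from compound 1 to compound 3 (0.49 log units; beyond the scatter) and compound 2 a 3.2-fold higher number from compound 1 to compound 2 (0.51 log units; beyond the scatter), both beyond the scatter, while compounds 2 and 3 lie within the scatter of each other a 1.0-fold lower number from compound 2 to compound 3 (0.02 log units; within the scatter).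

Compound 4 `COc1ccc(-c2cc(N)c(C(=O)c3cc(OC)c(OC)c(OC)c3)s2)cc1` differs from compound 1 in one place: methoxy in place of chloro on an aromatic carbon

The step to compound 3 bears most closely, since ethoxy is the nearest comparison for methoxy; the step to compound 2 shows the same direction. A modest rise is therefore expected in this assay for compound 4, a 2.3-fold higher number from compound 1 to compound 4 (0.37 log units; beyond the scatter). The estimate for compound 4 is 180 nM, range 80 nM to 400 nM.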

Compound 4, half-maximal inhibitory concentration: 18 nM
Beside the measured number, compound 4's estimate is 10-fold (1.00 log units) above it, and the stated range ends above it.
By their numbers in this assay, from the lowest: compound 4; then compound 1; then compounds 3 and 2 (each within the scatter of the next).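

In this assay the change to 4-methoxyphenyl runs opposite to the other two replacements of chloro, lowering the number (a 4.3-fold lower number from compound 1 to compound 4 (0.63 log units; beyond the scatter)), whereas ethoxy and trifluoromethyl both raised it. Removing one methyl from the ethoxy group gives a large step (a 13-fold lower number from compound 3 to compound 4 (1.12 log units; beyond the scatter)), so close analogues at this position are not interchangeable, and the step from trifluoromethyl is also large (a 14-fold lower number from compound 2 to compound 4 (1.14 log units; beyond the scatter)). Nothing available accounts for this difference between methoxy and ethoxy.

Open, from the compounds shown here alone, is how a hydroxy group, an amine or a propoxy chain would read at this position. Also open, going by these compounds, is whether fluoro would follow chloro or methoxy.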